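A few compounds are considered here, and "the series" means these few. Any claim that something is new, unique, unknown or untested is made for them only; others in the source may bear on it.

Measured so far in a functional assay on CCRF-SB cells (Homo sapiens) for antiproliferative activity, read by MTT assay, with a stated time of 96 h; a lower number here means a stronger inhibitor, a higher number a weaker inhibitor: compound 1 `O=C1NN(c2ccc([N+](=O)[O-])cc2)C(=O)C2(CSC3=C2C(=O)c2ncccc2C3=O)N1` gives 2 nM. Compound 2 `Cc1ccc(N2NC(=O)NC3(CSC4=C3C(=O)c3ncccc3C4=O)C2=O)cc1` gives 37 nM. Compound 3 `O=C1C2=C(C(=O)c3ncccc31)C1(CS2)NC(=O)N(c2ccc([N+](=O)[O-])cc2)C1=O` gives 2 nM. Compound 4 `Cc1ccc(N2C(=O)NC3(CSC4=C3C(=O)c3ncccc3C4=O)C2=O)cc1` is not yet measured.

Compounds 1 and 2 differ in one place, (methyl in place of nitro on an aromatic carbon), and that change made a 19-fold higher number from compound 1 to compound 2 (1.27 log units; beyond the scatter). Compound 3 sits level with compound 1, and the difference between the two cores of compound 1 and compound 3 is not broken down here. Compound 4 repeats the same change on compound 3, (methyl in place of nitro on an aromatic carbon), at a place described in exactly the same words, so it is the same change seen a second time. Going by the values given here, the step from compound 3 to compound 4 in this assay is expected to be of similar size, a 19-fold higher number from compound 3 to compound 4 (1.28 log units; beyond the scatter), resting on the single earlier step of a 19-fold higher number from compound 1 to compound 2 (1.27 log units; beyond the scatter). Compound 4 is therefore estimated at about 38 nM, most likely between 12 nM and 120 nM.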

Compound 4, half-maximal inhibitory concentration: 20 nM
For compound 4 the middle estimate is 1.9-fold (0.28 log units) above the measured one; low and high end bracket the measured number.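

In this assay replacing 4-nitrophenyl with 4-methylphenyl gives a 10-fold higher number from compound 3 to compound 4 (1.00 log units; beyond the scatter) and so the methyl compound is again the weaker inhibitor. The size of the step carried over from one core to the other, as the two steps agree as closely as repeated measurements allow: the same change on two cores in this assay, a 19-fold higher number (1.27 log units; beyond the scatter) from compound 1 to compound 2 and a 10-fold higher number (1.00 log units; beyond the scatter) from compound 3 to compound 4, 1.9-fold (0.27 log units) apart, within the scatter of two such steps. Going by these compounds alone, this rests on only two matched pairs, so it shows neither that the change would behave the same way on any further core nor why it lowers activity.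

The compounds shown leave open how other groups at this place would behave, such as an amine, a carboxylic acid or a longer carbon chain. They also leave open whether the step holds in other cell lines.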